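The source may report more compounds than this note shows. Statements on the series, on what has been measured and on what is new or still open speak of the compounds shown alone.

In a physicochemical assay for acid dissociation, compound 1 `COc1ccc(Oc2ccc3c(NCCCNCc4cc(F)ccc4OC)ccnc3c2)cc1` gives 9.28, compound 2 `COc1ccc(F)cc1CNCCCNc1ccnc2cc(C3CCCCC3)ccc12` gives 9.47, and compound 3 `FC(F)(F)c1cccc(Cc2ccc3c(NCCCNCc4ccco4)ccnc3c2)c1` gives 9.47. Compound 3 thus sits level with compound 2 at the digits shown, the two together at the top of the three numbers, while compound 1 lies a little lower, within the scatter. Going by the values given here, the only measured step, a number 0.19 log units higher from compound 1 to compound 2 (within the scatter), concerns a different part of the molecule and does not cover the change at hand. Compound 4 `COc1ccc(F)cc1CNCCCNc1ccnc2cc(Cc3cccc(C(F)(F)F)c3)ccc12` differs from compound 3 by 5-fluoro-2-methoxyphenyl in place of furan-2-yl on a saturated chain carbon bound to an amine nitrogen. Compounds 1 and 2 already carry the entering group and both fall close to compound 3. For compound 4 no shift beyond the scatter is expected, a step of a number 0.03 log units higher from compound 3 to compound 4 (within the scatter). Compound 4 is therefore estimated at 9.5, between 9.2 and 9.8.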

Compound 4, acid dissociation constant: 9.47
Compound 4: middle estimate off by 0.03 log units, on the high side, and the stated range covers the measured number.
By their numbers in this assay, from the lowest: compounds 1, 2, 3 and 4 (each within the scatter of the next).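

In this assay, the change at the saturated chain carbon bound to an amine nitrogen, 5-fluoro-2-methoxyphenyl in place of furan-2-yl, can now be read directly: no change at the digits printed from compound 3 to compound 4 (within the scatter). On an aromatic carbon, 3-(trifluoromethyl)benzyl in place of cyclohexyl gives no change at the digits printed from compound 2 to compound 4 (within the scatter), and in place of 4-methoxyphenoxy it gives a number 0.19 log units higher from compound 1 to compound 4 (within the scatter). No supporting data offer an explanation for these readings.

Still open, from the compounds shown here alone, is whether a carboxylic acid or a primary amine on that same chain carbon would move the number beyond the scatter.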